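A few compounds are considered here, and "the series" means these few. Any claim that something is new, unique, unknown or untested is made for them only; others in the source may bear on it.

Compound 1 `CS(=O)(=O)Oc1c(C(=O)NCc2ccc(F)cc2)nc(Br)c2cccnc12` offers no exact potency to build on. In a functional assay on HCT-116 cells (Homo sapiens) for cytotoxicity, read by MTT assay, with a stated time of 72 h (on this read-out higher numbers stand for weaker inhibition and lower numbers for stronger inhibition), compound 1 gives > 20000 nM, which is a limit rather than a measured number. For the measured compounds named here, compound 2 `N[C@H]1CC[C@H](Nc2c(C(=O)NCc3ccco3)nc(Br)c3cccnc23)CC1` is the only other compound tested so far. In this assay, compound 2 gives > 10000 nM, which is also a limit. Going by the values given here, neither result can therefore be ranked against the other, and no measured step yet shows how much a single change matters on this core.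

The next compound is compound 3 `C[C@@H](Nc1c(C(=O)NCc2ccc(F)cc2)nc(Br)c2cccnc12)c1ccccc1`, in which (1-phenylethyl)amino replaces (methylsulfonyl)oxy on an aromatic carbon ((1-phenylethyl)amino in place of (methylsulfonyl)oxy on an aromatic carbon). The new group brings a six-membered aromatic ring of carbon only and one defined stereocentre. Among the compounds with values here, with no measured step as a guide, only a modest shift toward stronger inhibition is expected in this assay, and it may not clear the scatter. The expected change is an at least 2.5-fold lower number from compound 1 to compound 3 (0.39 log units; beyond the scatter). A reported limit instead of a number remains a real possibility, as the limit seen for compound 2 at > 10000 nM suggests. For compound 3, the estimated half-maximal inhibitory concentration is 8000 nM, with an expected range from 1500 nM to 30000 nM.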

Compound 3, half-maximal inhibitory concentration: > 20000 nM
Compound 3 gave a limit, no number; the forecaster's own chance of this, stated with the estimate: 50%; middle value at least 2.5-fold (0.39 log units) away from the limit.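

Compound 1 and compound 3 both give only a limit in this assay, so the step between them cannot be read, and putting (1-phenylethyl)amino in place of (methylsulfonyl)oxy has no measurable size here. The compounds shown leave open which change on the shared core, if any, would give an exact number in this assay.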